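Replacing the 1,3-benzothiazol-2-yl group of compound 1

The source may hold more compounds than are shown below. What is called first, only, known or untested is meant among the compounds shown, and "the series" means these compounds.

Compound 1 `O=C(Nc1cccc(-c2nc3ccccc3s2)c1)c1cc([N+](=O)[O-])ccc1Cl`: 580 nM
Compound 2 `O=C(Nc1ccc(Cl)c(-c2nc3ccccc3s2)c1)c1cc([N+](=O)[O-])ccc1Cl`: 410 nM
Compound 3 `O=C(Nc1cc(-c2nc3ccccc3s2)ccc1Cl)c1cc([N+](=O)[O-])ccc1Cl`: 100 nM

In a physicochemical assay for solubility, read by spectrophotometry, in phosphate buffer, measured as kinetic solubility, with a stated time of 18 h, at pH 7.4 (a higher number here means a more soluble compound, a lower number a less soluble compound), compound 1 gives 580 nM. The two measured steps away from it are a 1.4-fold lower number from compound 1 to compound 2 (0.15 log units; within the scatter) and a 5.8-fold lower number from compound 1 to compound 3 (0.76 log units; beyond the scatter). Compound 1 thus stands clear of compound 3 but cannot be separated from compound 2.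

Compound 4 `O=C(Nc1cccc(-c2nc3ccccc3[nH]2)c1)c1cc([N+](=O)[O-])ccc1Cl` carries a different change: 1H-benzimidazol-2-yl in place of 1,3-benzothiazol-2-yl on an aromatic carbon. Both measured steps place chloro on an aromatic carbon, so neither measures this exchange directly. They serve only as a rough gauge of size, and a modest step is expected. The expected direction is towards a higher number, a 2.6-fold higher number from compound 1 to compound 4 (0.41 log units; beyond the scatter). For compound 4 the estimate is 1500 nM, with an expected range of 400 nM to 6000 nM.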

Compound 4, solubility: 1400 nM
For compound 4 the middle estimate is 1.1-fold (0.03 log units) above the measured one; low and high end bracket the measured number.
By their numbers in this assay, from the lowest: compound 3; then compounds 2 and 1 (each within the scatter of the next); then compound 4.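

At this position, in this assay, exchanging 1,3-benzothiazol-2-yl for 1H-benzimidazol-2-yl gives a 2.4-fold higher number from compound 1 to compound 4 (0.38 log units; beyond the scatter) and so moves the number upward, which neither chloro step from compound 1 did. The entering group keeps the two-ring aromatic form and the heavy-atom count of the leaving group, but it carries a hydrogen-bond donor that the leaving group lacks. Nothing measured here explains the rise.

As far as these compounds go, whether the step would hold with the chloro of compound 2 or compound 3 present remains open. So does how a simple amine or a carboxylic acid would compare at this position.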